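The source may report more compounds than this note shows. Statements on the series, on what has been measured and on what is new or still open speak of the compounds shown alone.

Measured compounds:
compound 1 `O=C(COc1cccc2ccccc12)N/N=C/c1cccc([N+](=O)[O-])c1` — 12.1 ug/mL
compound 2 `O=C(COc1cccc2ccccc12)N/N=C/c1ccccc1[N+](=O)[O-]` — 12.2 ug/mL
compound 3 `C/C(=N\NC(=O)COc1cccc2ccccc12)c1ccc(O)cc1O` — 59.9 ug/mL

These three numbers come from an ADME assay on MT4 cells (Homo sapiens) for cytotoxicity, read by MTT assay, with a stated time of 4 days; on this read-out lower numbers stand for higher toxicity in this test and higher numbers for lower toxicity in this test. Compound 2 holds the second highest of them. Its nearest neighbour is compound 1, whose number lies within the scatter of that of compound 2, so the two cannot be ranked against each other. Its furthest neighbour is compound 3, whose number is beyond the scatter and higher than that of compound 2.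

The step now followed leads from compound 2 to compound 4 `O=C(COc1cccc2ccccc12)N/N=C/c1ccccc1Cl`, which has not yet been tested in this assay. The change is chloro in place of nitro on an aromatic carbon. Within the data shown here, no measured pair shows what this change does here, so the expectation rests on the closeness of compound 1 and compound 2 alone. Compound 4 is expected to give a number near that of compound 2, with the step of a 1.2-fold higher number from compound 2 to compound 4 (0.09 log units; within the scatter) estimated to stay within the scatter. Compound 4 is estimated at 15 ug/mL, in a range from 5 ug/mL to 45 ug/mL.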

Compound 4, half-maximal cytotoxic concentration: 56.2 ug/mL
For compound 4 the middle estimate is 3.7-fold (0.57 log units) below the measured one; the measured number lies above the stated range.
By their numbers in this assay, from the lowest: compounds 1 and 2 (each within the scatter of the next); then compounds 4 and 3 (each within the scatter of the next).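

In this assay, chloro in place of nitro on an aromatic carbon, ortho to a large group, gives a 4.6-fold higher number from compound 2 to compound 4 (0.66 log units; beyond the scatter), a step beyond the scatter towards lower toxicity in this test. The substituent at this position therefore matters, which the closeness of compound 1 and compound 2 had not revealed. Nothing available explains why the number moves.

On these data alone, it remains open whether the step comes from losing nitro or from gaining chloro. An amine or a methoxy group on the same carbon could separate these two readings.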